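A few compounds are considered here, and "the series" means these few. Any claim that something is new, unique, unknown or untested is made for them only; others in the source may bear on it.

Working notes on the series. Compound 1 `O=C1OC(c2ccc(Cl)cc2)=C/C1=C\c1ccc(Cl)cc1` gives 69.1% in a functional assay on the whole organism (strain Wistar) for inhibition, with Rattus norvegicus as the target, with stated times of 30 min and 3 h, at a dose of 20 mg/kg by the oral route; a lower number here means less inhibition, a higher number more inhibition at the dose given (going by the name of the read-out). Compound 2 `O=C1OC(c2ccc(Cl)cc2)=C/C1=C\c1ccc(Cl)cc1Cl` differs from compound 1 by chloro in place of hydrogen on an aromatic carbon; in this assay compound 2 gives 72.6%, and the step of a number 3.5 percentage points higher from compound 1 to compound 2 (within the scatter) is within the scatter. Compound 3 `O=C1/C(=C/c2ccccc2)C=C(c2ccc(Cl)cc2)N1Cc1ccccc1` has a different core; the difference between the two cores is not broken down here. In this assay compound 3 gives 37%, the lowest of the three numbers. Compound 4 `O=C1/C(=C/c2ccc(Cl)cc2)C=C(c2ccc(Cl)cc2)N1Cc1ccccc1` is not yet measured; it differs from compound 3 by chloro in place of hydrogen on an aromatic carbon. This is the same kind of change as from compound 1 to compound 2, not the same: there the chloro enters ortho to a large group and meta to a chloro group, here para to a large group. Because a number 3.5 percentage points higher from compound 1 to compound 2 (within the scatter) is within the scatter, a step of a number 5 percentage points higher from compound 3 to compound 4 (within the scatter) is expected. Compound 4 is estimated at 42%, between 25% and 60%.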

Compound 4, a percentage reported as inhibition, in the whole organism at one dose (the size of the read-out at that dose, not a potency): 88.9%
Estimate against measurement, compound 4: 46.9 percentage points below; the whole stated range lies below it.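

In this assay the change of hydrogen to chloro gives a number 51.9 percentage points higher from compound 3 to compound 4 (beyond the scatter), so the size of this step does not carry from one core to the other in this series: the same change on two cores in this assay, a number 3.5 percentage points higher (within the scatter) from compound 1 to compound 2 and a number 51.9 percentage points higher (beyond the scatter) from compound 3 to compound 4, 48.4 percentage points apart, beyond the scatter of two such steps

The chloro also enters at a different place in each pair, para to a large group in compound 4, so these two pairs do not separate an effect of the core from one of position. Nor do they show how the step would behave on any further core.

From the compounds shown here alone, it remains open whether the large step on the core of compound 3 is specific to chloro or also appears with another group at that place, such as methoxy, an amine or a carboxylic acid.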